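A chloro group added to compound 2

The compounds below may be only part of what the source reports. "The series", "measured", "known", "first", "only" and "open" are said of these compounds alone.

Values in a functional assay on PC-3 cells (Homo sapiens) for antiproliferative activity, read by MTT assay, with a stated time of 96 h; on this read-out higher numbers stand for weaker inhibition of growth and lower numbers for stronger inhibition of growth:
Compound 1 `c1ccc(Nc2ccc3ccccc3n2)nc1`: > 30000 nM, a limit of the assay
Compound 2 `COc1cccc2ccc(Nc3ccccn3)nc12`: 7470 nM

Among the compounds with values here, compound 2 holds the only actual number of the pair, since the other entry is a limit. Compound 3 `COc1ccc(Cl)c2ccc(Nc3ccccn3)nc12` has not yet been measured in this assay. It differs from compound 2 by one change: chloro in place of hydrogen on an aromatic carbon, with chloro in place of hydrogen on an aromatic carbon, para to a methoxy group. Within the data shown here, only one measured step bears on this, and only indirectly: an at least 4.0-fold lower number from compound 1 to compound 2 (0.60 log units; beyond the scatter). That step is a different substitution on the shared core, so it offers a weak hint of direction and no direct measure for chloro. A modest further fall is expected on the strength of that single step, though a change within the scatter remains quite possible. The expected size is a 2.5-fold lower number from compound 2 to compound 3 (0.40 log units; beyond the scatter). For compound 3 the estimated value is 3000 nM, with an expected range from 700 nM to 12000 nM.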

Compound 3, concentration for 50% growth inhibition: 29200 nM
For compound 3 the middle estimate is 9.7-fold (0.99 log units) below the measured one, outside the stated range (above it).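

In this assay, chloro in place of hydrogen on an aromatic carbon, para to a methoxy group, gives a 3.9-fold higher number from compound 2 to compound 3 (0.59 log units; beyond the scatter) and so weakens growth inhibition beyond the scatter. Within the data shown here, the earlier compounds showed only a methoxy step that came with stronger inhibition, so this is the first sign that a further substituent on this six-membered aromatic ring of carbon only can move the number the other way. Adding a group to the shared core therefore does not in itself strengthen inhibition, and here a single chlorine atom is enough to reverse the direction.

The compounds shown leave open whether fluoro, methyl or an amine on this carbon would also raise the number, and whether chloro would do so without the methoxy group. Compound 1 stands at a limit of the assay, so how far any further rise could be followed is restricted: the limit of > 30000 nM in this assay, at which 1 of the 3 values shown sits.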